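The compounds below may be only part of what the source reports. "The series", "measured", "known", "first", "only" and "open" are said of these compounds alone.

Of the compounds shown here, two have been measured in an in vitro ADME assay on microsomes from liver (Homo sapiens) for metabolic stability; on this read-out lower numbers stand for a shorter-lived compound and higher numbers for a longer-lived compound. Compound 1, `COc1ccc(-c2cc(-c3ccc(S(N)(=O)=O)cc3)cnc2N)cn1`, gives > 4.16 h, which is a limit of the assay rather than a number. Compound 2, `COc1ccc(-c2cc(-c3ccc(NS(C)(=O)=O)cc3)cnc2N)cn1`, gives > 4.16 h, again a limit. The step that the two limits leave unreadable from compound 1 to compound 2 cannot be read because of the limit of > 4.16 h in this assay, at which 2 of the 2 values shown sit. Compound 3, `COc1ccc(-c2cc(-c3ccc(C(N)=O)cc3)cnc2N)cn1`, has not yet been measured and differs from compound 2 by carbamoyl in place of methanesulfonamido on an aromatic carbon. Among the measured compounds shown here, no measured step bears on this change, so its size and direction cannot be inferred from the data. The expected step is a step that the limit leaves unreadable from compound 2 to compound 3, meaning no shift beyond the scatter. Compound 3 is therefore estimated at 4.5 h, within 2 h to 8 h.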

Compound 3, half-life: > 4.16 h
Compound 3 was reported as a limit; the forecaster's own chance of this, stated with the estimate: 65%; the middle value does not contradict the limit.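

No step among compound 1, compound 2 and compound 3 can be read, because all three values are limits rather than numbers: the limit of > 4.16 h in this assay, at which 3 of the 3 values shown sit.

The compounds shown leave open how long each one actually lasts in this assay, and whether the sulfamoyl, methanesulfonamido and carbamoyl groups differ there at all.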